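The source may hold more compounds than are shown below. What is called first, only, known or untested is meant among the compounds shown, and "the series" means these compounds.

Compound 1 `CN1CCC(C(=O)N2Cc3c(NC(=O)Nc4cccc(F)c4)n[nH]c3C2(C)C)CC1` was measured in a physicochemical assay for solubility, at pH 7; on this read-out higher numbers stand for higher solubility and lower numbers for lower solubility. In that assay compound 1 gives > 225000 nM, which is a limit of the assay and not a number. Compound 2 `CN(C)CC(=O)Nc1n[nH]c2c1CN(C(=O)C(C)(C)C)C2(C)C` gives > 225000 nM in this assay, also a limit. Compound 3 `CCN1CCC(C(=O)N2Cc3c(NC(=O)c4ccc(F)cc4)n[nH]c3C2(C)C)CC1` gives > 225000 nM in this assay, again a limit. All three values shown rest on (the limit of > 225000 nM in this assay, at which 3 of the 3 values shown sit), so compound 1 stands where every measured compound stands, with no number to set it apart from the others. Among the compounds with values here, no two measured compounds differ in one place, so no step in this assay can be read off from them. The unmeasured compound 4 `CN1CCC(C(=O)N2Cc3c(NC(=O)NCc4ccccc4)n[nH]c3C2(C)C)CC1` differs from compound 1 in a single place: benzyl in place of 3-fluorophenyl on an amide-type nitrogen. With every measured value sitting at the limit, the expected step is a number no higher from compound 1 to compound 4 (the limit leaves the size open), none beyond the scatter, and compound 4 is expected to stay at the limit as well. Compound 4 is estimated at 225000 nM, with a range from 110000 nM to 450000 nM.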

Compound 4, solubility: > 225000 nM
Compound 4: only a limit was reported; the forecaster's own chance of this, stated with the estimate: 75%; the middle value sits exactly at the limit.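

Compound 1 and compound 4 both rest on a limit of the assay and not on a number, so no step can be read between them: the limit of > 225000 nM in this assay, at which 4 of the 4 values shown sit.

The compounds shown leave open how far apart any of them lie in this assay, and which change, if any, would give a readable number.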